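Moving the chlorine around the urea-linked phenyl ring

This account rests on a few compounds, and the source may have more. Where it says the series, first, only, none or still open, it means among the compounds named here.

Three ureas sharing one core have been measured in an assay on isolated protein for inhibition of Polyunsaturated fatty acid 5-lipoxygenase (Homo sapiens), read by HPLC, with a stated time of 10 min; a higher number here means a weaker inhibitor, a lower number a stronger inhibitor. Compound 1 `Cc1cc(NC(=O)Nc2ccc(Cl)cc2)ccc1OCc1nc2ccccc2s1` carries a methyl group on the ether-bearing ring and a chlorine on the far phenyl ring. Compound 1 reaches only the upper limit of this assay, > 10000 nM, which is a limit and not a number; this is the situation described by the limit of > 10000 nM in this assay, at which 1 of the 3 values shown sits. Compound 2 `O=C(Nc1ccc(OCc2nc3ccccc3s2)cc1)Nc1ccccc1Cl` lacks the methyl and carries its chlorine as a 2-chlorophenyl group; in this assay compound 2 gives 360 nM. Compound 3 `O=C(Nc1ccc(OCc2nc3ccccc3s2)cc1)Nc1cccc(Cl)c1` carries a 3-chlorophenyl group instead, and in this assay compound 3 gives 170 nM, the lowest of the two numbers shown. Among the measured compounds shown here, the single measured step, a 2.1-fold lower number from compound 2 to compound 3 (0.33 log units; beyond the scatter), shows that moving the chlorine from one position of the ring to another shifts the number modestly but beyond the scatter.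

Compound 4 `O=C(Nc1ccc(Cl)cc1)Nc1ccc(OCc2nc3ccccc3s2)cc1` is not yet measured. It differs from compound 3 as follows: 4-chlorophenyl in place of 3-chlorophenyl on an amide-type nitrogen. For the measured compounds named here, only the step from compound 2 to compound 3 bears on this change, and it moved the chlorine within the same ring by a modest amount. A step of similar size in either direction is therefore plausible for compound 4; the expected outcome is a 1.8-fold higher number from compound 3 to compound 4 (0.25 log units; within the scatter). Compound 4 is estimated at 300 nM, with a range from 80 nM to 3000 nM.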

Compound 4, half-maximal inhibitory concentration: 1010 nM
For compound 4 the middle estimate is 3.4-fold (0.53 log units) below the measured one; measured number inside the range.
By their numbers in this assay, from the lowest: compound 3; then compound 2; then compound 4. At a limit, above all of these: compound 1.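

Where the chlorine sits on this ring matters more than the earlier step suggested. In this assay, the change to the 4-chlorophenyl group gives a 5.9-fold higher number from compound 3 to compound 4 (0.77 log units; beyond the scatter) and, measured against the 2-chlorophenyl group, a 2.8-fold higher number from compound 2 to compound 4 (0.45 log units; beyond the scatter), so compound 4 has the highest number of the three ureas without the methyl group. Compound 4 also pairs directly with compound 1, and having hydrogen in place of methyl on an aromatic carbon gives an at least 9.9-fold lower number from compound 1 to compound 4 (0.99 log units; beyond the scatter), so the 4-chlorophenyl group alone does not account for the loss seen with compound 1. Compound 1 stands at a limit and not at a number: the limit of > 10000 nM in this assay, at which 1 of the 4 values shown sits.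

Chlorine is the only group shown on this ring, so it remains open whether fluorine, a methoxy group or a carboxylic acid would give the same order across these three positions. On these data alone, the methyl change can be read only alongside the 4-chlorophenyl group, so its size alongside the 2-chlorophenyl or 3-chlorophenyl group also remains open.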